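A Branched Carbamate Ester Takes the Place of Fluoroethyl

A few compounds are considered here, and "the series" means these few. Any claim that something is new, unique, unknown or untested is made for them only; others in the source may bear on it.

Going by the values given here, compound 3 `Cc1nc(S(C)(=O)=O)ccc1Oc1ncnc(OC2CCN(C(=O)OC(C)F)CC2)c1F` gives 315 nM in a functional assay on isolated protein for inhibition of Glucose-dependent insulinotropic receptor (Rattus norvegicus), read by HTRF and cAMP accumulation (on this read-out higher numbers stand for an effect only at larger amounts of compound and lower numbers for an effect already at smaller amounts), the highest of the three numbers measured so far. Its nearest neighbour is compound 1 `Cc1nc(S(C)(=O)=O)ccc1Oc1ncnc(OC2CCN(C(=O)OC3CCC3)CC2)c1F` with 167 nM, and the step of a 1.9-fold higher number from compound 1 to compound 3 (0.28 log units; within the scatter) stays within the scatter. Its furthest neighbour is compound 2 `Cc1nc(S(C)(=O)=O)ccc1Oc1ncnc(OC2CCN(C(=O)OC(C)(C)C(F)(F)F)CC2)c1F` with 47.2 nM, and the step of a 6.7-fold higher number from compound 2 to compound 3 (0.82 log units; beyond the scatter) is beyond the scatter. Compound 4 `CCC1(OC(=O)N2CCC(Oc3ncnc(Oc4ccc(S(C)(=O)=O)nc4C)c3F)CC2)CC1` differs from compound 3 by 1-ethylcyclopropyl in place of 1-fluoroethyl on an oxygen next to a carbonyl group. The entering group, like that of compound 2, is branched at the carbon on the oxygen, so the step of a 6.7-fold higher number from compound 2 to compound 3 (0.82 log units; beyond the scatter) bears most on this change and points to a modest move towards lower numbers in this assay. Compound 4 is therefore expected to give 70 nM in this assay, with a range from 25 nM to 200 nM. This estimate means an expected step of a 4.5-fold lower number from compound 3 to compound 4 (0.65 log units; beyond the scatter).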

Compound 4, half-maximal effective concentration: 333 nM
Estimate against measurement, compound 4: 4.8-fold (0.68 log units) below; the whole stated range lies below it.
By their numbers in this assay, from the lowest: compound 2; then compounds 1, 3 and 4 (each within the scatter of the next).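

In this assay, branching at the carbon on the oxygen does not by itself give the low number of compound 2: the step of a 1.1-fold higher number from compound 3 to compound 4 (0.02 log units; within the scatter) brings no separation from the unbranched-looking 1-fluoroethyl case, while the step of a 7.1-fold higher number from compound 2 to compound 4 (0.85 log units; beyond the scatter) keeps compound 2 apart. With the step of a 2.0-fold higher number from compound 1 to compound 4 (0.30 log units; within the scatter) as well, compounds 1, 3 and 4 sit together, and among these groups only 1-methyl-1-(trifluoromethyl)ethyl stands apart. Nothing measured here accounts for this. Going by these compounds, whether a tert-butyl group or a 1-(trifluoromethyl)cyclopropyl group on this oxygen would match compound 2 remains open.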